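Spiro series: sulfamoylphenyl analogue of compound 2

The source may hold more compounds than are shown below. What is called first, only, known or untested is meant among the compounds shown, and "the series" means these compounds.

Compound 1 `N#CC1=C(N)Oc2c(c3nc4ccccc4nc3c3ccccc23)C12C(=O)N(Cc1cnnn1-c1cccc(Cl)c1)c1ccccc12` and compound 2 `N#CC1=C(N)Oc2c(c3nc4ccccc4nc3c3ccccc23)C12C(=O)N(Cc1cnnn1-c1ccc(N)cc1)c1ccccc12` share one core and differ only at the aromatic nitrogen. In a functional assay on HepG2 cells (Homo sapiens) for antiproliferative activity, read by MTT assay, with a stated time of 48 h (on this read-out lower numbers stand for stronger inhibition and higher numbers for weaker inhibition), compound 1 reaches only the limit > 50000 nM. In this assay compound 2 likewise reaches only the limit > 50000 nM. The step that the two limits leave unreadable from compound 1 to compound 2 is unreadable, as the limit of > 50000 nM in this assay, at which 2 of the 2 values shown sit, shows. Compound 3 `N#CC1=C(N)Oc2c(c3nc4ccccc4nc3c3ccccc23)C12C(=O)N(Cc1cnnn1-c1ccc(S(N)(=O)=O)cc1)c1ccccc12` carries sulfamoyl in place of amino on an aromatic carbon, para to a large group; read one bond further out, 4-aminophenyl becomes 4-sulfamoylphenyl. Among the compounds with values here, no measured step bears on this change, and compound 2 gives only a limit. The expected step of a number no higher from compound 2 to compound 3 (the limit leaves the size open) is none that this assay could resolve. For compound 3 the estimate is 50000 nM, between 20000 nM and 200000 nM, most likely again a limit.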

Compound 3, half-maximal inhibitory concentration: 42200 nM
Compound 3: middle estimate off by 1.2-fold (0.07 log units), on the high side; low and high end bracket the measured number.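

In this assay, within the data shown here, the 4-sulfamoylphenyl group gives the first number of the series rather than a limit: compound 3 reads 42200 nM. Set against the two limits, the change reads as an at least 1.1-fold lower number from compound 2 to compound 3 (0.07 log units; that floor lies within the scatter) and as an at least 1.1-fold lower number from compound 1 to compound 3 (0.07 log units; that floor lies within the scatter). Both are floors, so no gain beyond the scatter is shown at this position, and the true size of each step stays open: the limit of > 50000 nM in this assay, at which 2 of the 3 values shown sit.

Nothing shown tells whether a carboxylic acid or a methylsulfonyl group on the same aromatic carbon would also give a number in this assay, or a lower one than compound 3.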